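Amide variation on the shared core: efficacy estimate for compound 4

The source may report more compounds than this note shows. Statements on the series, on what has been measured and on what is new or still open speak of the compounds shown alone.

Measured compounds:
- compound 1 `CSc1nc(-c2cccc(F)c2)c2c(N)c(C(=O)NC(C)(C)C)sc2n1`: 8.1%
- compound 2 `COc1cccc(-c2nc(SC)nc3sc(C(=O)NN)c(N)c23)c1`: 6.1%
- compound 3 `COc1cccc(-c2nc(SC)nc3sc(C(=O)NCCO)c(N)c23)c1`: 2.9%

All three give small maximal responses in a functional assay on HEK293 cells for agonist activity at Thyrotropin receptor (Homo sapiens), read by cAMP accumulation; on this read-out lower numbers stand for smaller maximal responses and higher numbers for larger maximal responses. Compound 2 sits alongside compounds 1 and 3: its gap to compound 1 is within the scatter, and the step of a number 3.2 percentage points lower from compound 2 to compound 3 (within the scatter) is within the scatter as well.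

Compound 4 `COc1cccc(-c2nc(SC)nc3sc(C(=O)N(C)C)c(N)c23)c1` differs from compound 2 by dimethylamino in place of aminoamino on a carbonyl carbon. Going by the values given here, the only step on the same carbonyl, a number 3.2 percentage points lower from compound 2 to compound 3 (within the scatter), did not move the response beyond the scatter, and no change across compounds 1 to 3 has done so. No step beyond the scatter is therefore expected in this assay, in either direction.

Compound 4 is estimated at 5%, with a range of 0% to 13%. This estimate means a step of a number 1.1 percentage points lower from compound 2 to compound 4 (within the scatter), expected to stay within the scatter.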

Compound 4, largest response reached (reported as efficacy), in percent of the reference or control that the assay uses: 4%
The estimate for compound 4 lay 1 percentage points above the measured number; low and high end bracket the measured number.
By their numbers in this assay, from the lowest: compounds 3, 4, 2 and 1 (each within the scatter of the next).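

In this assay the carbonyl carbon takes dimethylamino, with 0 hydrogen-bond donors, in place of aminoamino, with 2, and the result is a number 2.1 percentage points lower from compound 2 to compound 4 (within the scatter) on the shared core. Set against (2-hydroxyethyl)amino, the same group gives a number 1.1 percentage points higher from compound 3 to compound 4 (within the scatter) and so adds a third group at this place with no step beyond the scatter. No available evidence accounts for this flat response.

As far as these compounds go, whether a carboxylic acid or a piperazine amide at this carbonyl carbon would move the response beyond the scatter remains open. Also open, from the compounds shown here alone, is whether any change away from this carbonyl would do so.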